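Adding a bromo group to the core of compound 2

The compounds below may be only part of what the source reports. "The series", "measured", "known", "first", "only" and "open" are said of these compounds alone.

Of the compounds shown here, three with one shared core have been tested in a functional assay on MCF7 cells (Homo sapiens); a higher number here means a weaker inhibitor of growth, a lower number a stronger inhibitor of growth. Compound 1 `O=S(=O)(/C=C/c1ccccc1)Cc1ccc(Nc2ncnc3ccccc23)cc1`, which carries a plain phenyl, gives 74000 nM. Compound 2 `O=S(=O)(/C=C/c1ccc(Cl)c(Cl)c1)Cc1ccc(Nc2ncnc3ccccc23)cc1`, with 3,4-dichlorophenyl instead, gives 28000 nM, and compound 3 `O=S(=O)(/C=C/c1ccc(Cl)cc1Cl)Cc1ccc(Nc2ncnc3ccccc23)cc1`, with 2,4-dichlorophenyl, gives 4000 nM. Compound 2 thus holds the second highest of the three numbers.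

Compound 4 `O=S(=O)(/C=C/c1ccc(Cl)c(Cl)c1)Cc1ccc(Nc2ncnc3ccc(Br)cc23)cc1` keeps the 3,4-dichlorophenyl of compound 2 and changes the core instead, with bromo in place of hydrogen on an aromatic carbon.

Within the data shown here, all the measured steps are changes at the phenyl, so none tests the core directly. The first is a 2.6-fold lower number from compound 1 to compound 2 (0.42 log units; beyond the scatter), the second is a 19-fold lower number from compound 1 to compound 3 (1.27 log units; beyond the scatter), and the third is a 7.0-fold lower number from compound 2 to compound 3 (0.85 log units; beyond the scatter). They bear on the new change only loosely. They show that a swap of one group can shift the number clearly in this small set, and that the two chlorine-bearing compounds both sit lower than compound 1.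

A modest step towards a lower number therefore seems the likeliest outcome, though with little certainty. The expected change is a 2.0-fold lower number from compound 2 to compound 4 (0.30 log units; within the scatter). For compound 4 the estimated value is 14000 nM, with an expected range from 3500 nM to 50000 nM.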

Compound 4, concentration for 50% growth inhibition: 14000 nM
Compound 4: the middle estimate sits on the measured number at the digits printed; the measured number falls inside the stated range.
By their numbers in this assay, from the lowest: compound 3; then compounds 4 and 2 (each within the scatter of the next); then compound 1.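

In this assay, the change at the core gives a 2.0-fold lower number from compound 2 to compound 4 (0.30 log units; within the scatter) and so places bromo and hydrogen on this aromatic carbon within the scatter of each other, with the 3,4-dichlorophenyl held constant. Among these compounds, this is the first direct reading at this position, which is meta to a fused ring and para to a fused ring, and it differs from the three phenyl steps, all of which lie beyond the scatter. No measured evidence is available here to explain the result.

The compounds shown leave open whether bromo on the core would read the same alongside the 2,4-dichlorophenyl of compound 3, which stands clearly apart from both compound 1 and compound 2. On these data alone, it is also open how a different group at this aromatic carbon, such as an amine, a methoxy group or a carboxylic acid, would compare with hydrogen and bromo, and whether bromo on another aromatic carbon of the same ring would give a step beyond the scatter.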